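A few compounds are considered here, and "the series" means these few. Any claim that something is new, unique, unknown or untested is made for them only; others in the source may bear on it.

Compound 1 `CC(C)Sc1nnc(-c2c(CNC3CC3)c3ccccc3n2C)n1-c1ccccc1` sits second highest of the three numbers in a physicochemical assay for lipophilicity (on this read-out higher numbers stand for higher lipophilicity and lower numbers for lower lipophilicity), giving 4.81. Compound 2 `COCCNCc1c(-c2nnc(SC(C)C)n2-c2ccccc2)n(C)c2ccccc12` gives 4.36 and compound 3 `CC(C)Sc1nnc(-c2c(CNCC3CC3)c3ccccc3n2C)n1-c1ccccc1` gives 5.24. The steps at the amine nitrogen are modest: a number 0.45 log units lower from compound 1 to compound 2 (beyond the scatter), a number 0.43 log units higher from compound 1 to compound 3 (beyond the scatter) and a number 0.88 log units higher from compound 2 to compound 3 (beyond the scatter). Compound 4 `CC(C)Sc1nnc(-c2c(CNc3nc4ccccc4[nH]3)c3ccccc3n2C)n1-c1ccccc1` carries the change (1H-benzimidazol-2-yl in place of cyclopropyl on an amine nitrogen). Among the measured compounds shown here, none of the measured steps puts an aromatic group on that nitrogen, so they only show that exchanges there move this assay by modest amounts. A somewhat larger shift upward is expected for compound 4, a number 0.29 log units higher from compound 1 to compound 4 (within the scatter), with wide uncertainty. The estimate for compound 4 is 5.1, between 4.4 and 5.8.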

Compound 4, partition coefficient: 5.94
Estimate against measurement, compound 4: 0.84 log units below, and the stated range ends below it.
By their numbers in this assay, from the lowest: compound 2; then compound 1; then compound 3; then compound 4.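

In this assay, 1H-benzimidazol-2-yl on the amine nitrogen gives the largest steps seen at this position (a number 1.13 log units higher from compound 1 to compound 4 (beyond the scatter)) and (a number 1.58 log units higher from compound 2 to compound 4 (beyond the scatter)), whereas the steps among cyclopropyl, cyclopropylmethyl and 2-methoxyethyl are all modest. Among the compounds shown here, the step from the highest of the earlier compounds is modest but still clear (a number 0.70 log units higher from compound 3 to compound 4 (beyond the scatter)), so compound 4 stands highest of the four. Nothing measured here explains the rise.

Still open, from the compounds shown here alone, is whether both rings of 1H-benzimidazol-2-yl are needed, or whether a phenyl group on the same nitrogen would give a similar number.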